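Swapping the Urea Aryl Group of Compound 3

The compounds below may be only part of what the source reports. "The series", "measured", "known", "first", "only" and "open" are said of these compounds alone.

Compound 1 `CCN(CC)C(=O)Nc1ccc(S(=O)(=O)Nc2cccc(-c3nc(-c4ccc(NC(=O)c5cccnc5)cc4Cl)no3)c2)cc1` gives 8700 nM in a functional assay on MDA-MB-231 cells (Homo sapiens) for antiproliferative activity, read by MTT assay, with a stated time of 72 h; on this read-out higher numbers stand for weaker inhibition and lower numbers for stronger inhibition. Compound 2 `O=C(Nc1ccc(-c2noc(-c3cccc(NS(=O)(=O)c4ccc(NC(=O)N5CCCCC5)cc4)c3)n2)c(Cl)c1)c1cccnc1` gives only a limit of this assay, > 10000 nM. Compound 3 `NS(=O)(=O)c1ccc(NC(=O)Nc2cccc(-c3nc(-c4ccc(NC(=O)c5cccnc5)cc4Cl)no3)c2)cc1` gives only a limit of this assay, > 10000 nM.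

Compound 3 therefore sits at the limit of > 10000 nM in this assay, at which 2 of the 3 values shown sit, with no exact number to build on. Compound 4 `CS(=O)(=O)Nc1ccc(NC(=O)Nc2cccc(-c3nc(-c4ccc(NC(=O)c5cccnc5)cc4Cl)no3)c2)cc1Br` differs from it in one place: 3-bromo-4-(methanesulfonamido)phenyl in place of 4-sulfamoylphenyl on an amide-type nitrogen. Within the data shown here, the single measured step, an at least 1.1-fold higher number from compound 1 to compound 2 (0.06 log units; that floor lies within the scatter), alters a different part of the shared core and stays within the scatter, so it says nothing about this change. With compound 3 known only as a limit, no direction can be read, and the step from compound 3 to compound 4 is expected to be a number no higher from compound 3 to compound 4 (the limit leaves the size open). Compound 4 is estimated at 10000 nM, with a range from 3000 nM to 30000 nM.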

Compound 4, half-maximal inhibitory concentration: 700 nM
The estimate for compound 4 lay 14-fold (1.15 log units) above the measured number; the whole stated range lies above it.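

Replacing 4-sulfamoylphenyl with 3-bromo-4-(methanesulfonamido)phenyl on the amide-type nitrogen gives an at least 14-fold lower number from compound 3 to compound 4 (1.15 log units; beyond the scatter) in this assay, the first step shown that lies beyond the scatter. This position therefore clearly affects the read-out, and compound 4 provides an exact number where compound 3 gave none. The full size of the step stays unknown because compound 3 is known only as a limit: the limit of > 10000 nM in this assay, at which 2 of the 4 values shown sit.

The bromine and the methanesulfonamido group enter together, so the compounds shown cannot separate their contributions. Nor do they show how a chlorine in place of the bromine, or an amine in place of the methanesulfonamido group, would fare.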